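This account rests on a few compounds, and the source may have more. Where it says the series, first, only, none or still open, it means among the compounds named here.

Compound 1 `Cc1ccc(C(=O)C(=C2NCCN2)c2c(Cl)c(Cl)c(C#N)c(Cl)c2C#N)cc1` and compound 3 `COc1ccc(C(=O)C(=C2NCCN2)c2c(Cl)c(Cl)c(C#N)c(Cl)c2C#N)cc1` share a core and differ by one change, (methoxy in place of methyl on an aromatic carbon). In a functional assay on K562 cells (Homo sapiens) for antiproliferative activity, read by MTT assay (a higher number here means a weaker inhibitor, a lower number a stronger inhibitor), compound 1 gives 1.4 ug/mL, while compound 3 gives 0.08 ug/mL, a step of an 18-fold lower number from compound 1 to compound 3 (1.24 log units; beyond the scatter). Compound 2 `Cc1ccc(C(=O)C(=C2NCCN2)c2c(Cl)c(F)c(C#N)c(F)c2C#N)cc1` has a different core, and the difference between the two cores is not broken down here; in this assay compound 2 gives 41.9 ug/mL, the highest of the three numbers. Compound 4 `COc1ccc(C(=O)C(=C2NCCN2)c2c(Cl)c(F)c(C#N)c(F)c2C#N)cc1` stands to compound 2 as compound 3 stands to compound 1: the change is methoxy in place of methyl on an aromatic carbon, at the same place as before, so it is the same change. For compound 4 a step of about a 14-fold lower number from compound 2 to compound 4 (1.15 log units; beyond the scatter) is expected, somewhat smaller than the earlier one because the earlier step of an 18-fold lower number from compound 1 to compound 3 (1.24 log units; beyond the scatter) was measured on a core that already gave a much lower number. On that basis compound 4 is estimated at 3 ug/mL, most likely between 0.8 ug/mL and 12 ug/mL.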

Compound 4, half-maximal inhibitory concentration: 22.6 ug/mL
Compound 4: the middle estimate sits 7.5-fold (0.88 log units) below what was measured; measured number above the stated range.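

In this assay the change from 4-methylphenyl to 4-methoxyphenyl gives a 1.9-fold lower number from compound 2 to compound 4 (0.27 log units; within the scatter) and on this core cannot be told apart from repeat-measurement noise. The size of the step did not carry over from one core to the other: the same change on two cores in this assay, an 18-fold lower number (1.24 log units; beyond the scatter) from compound 1 to compound 3 and a 1.9-fold lower number (0.27 log units; within the scatter) from compound 2 to compound 4, 9.4-fold (0.97 log units) apart, beyond the scatter of two such steps. A step measured on one of these cores is thus a poor guide to the other, but two cores give no general rule, and these numbers do not show why the steps differ. The compounds shown leave open whether other groups in the same place, such as an amine or a carboxylic acid, would behave alike on both cores. They also leave open how this change behaves on any further core.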